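The source may hold more compounds than are shown below. What is called first, only, known or untested is meant among the compounds shown, and "the series" means these compounds.

Measured compounds:
Compound 1 `O=C(c1ccc(Cl)c(C(F)(F)F)c1)N1CCC(n2cncc2-c2ccc(OS(=O)(=O)c3cccc4ccccc34)cc2)CC1` gives 3520 nM in an assay on HEK293 cells for antagonist activity at P2X purinoceptor 7 (Homo sapiens), read by fluorescence, with a stated time of 2 h; on this read-out higher numbers stand for weaker inhibition and lower numbers for stronger inhibition.
Compound 2 `O=C(NC1CC1)c1cccc(S(=O)(=O)Oc2ccc(-c3cncn3C3CCN(C(=O)c4ccc(Cl)c(C(F)(F)F)c4)CC3)cc2)c1` gives 88 nM in this assay.

Among these two, compound 2 stands with the lower number, and the step of a 40-fold lower number from compound 1 to compound 2 (1.60 log units; beyond the scatter) lies well beyond the scatter. That step changed only the group on the sulfonyl sulfur.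

Compound 3 `CS(=O)(=O)c1ccc(C(=O)N2CCC(n3cncc3-c3ccc(OS(=O)(=O)c4cccc(C(=O)NC5CC5)c4)cc3)CC2)cc1` differs from compound 2 at another place: 4-(methylsulfonyl)phenyl in place of 4-chloro-3-(trifluoromethyl)phenyl on a carbonyl carbon. No measured pair here changes this group, so the single known step does not bear on the move from compound 2 to compound 3, and nothing among these compounds shows how the assay responds at this position. With no guide, the expectation for compound 3 is best set near the number of compound 2, with a wide range on both sides, and an expected step of a 2.8-fold higher number from compound 2 to compound 3 (0.45 log units; beyond the scatter). Compound 3 is therefore estimated at 250 nM, with a range from 50 nM to 1500 nM.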

Compound 3, half-maximal inhibitory concentration: 400 nM
For compound 3 the middle estimate is 1.6-fold (0.20 log units) below the measured one, and the stated range covers the measured number.
By their numbers in this assay, from the lowest: compound 2; then compound 3; then compound 1.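

Within the data shown here, this is the first look at the group on the carbonyl carbon, and in this assay that group clearly matters: replacing 4-chloro-3-(trifluoromethyl)phenyl with 4-(methylsulfonyl)phenyl gives a 4.5-fold higher number from compound 2 to compound 3 (0.66 log units; beyond the scatter) as a modest loss of inhibition. The position still accepts a quite different group, one with 2 hydrogen-bond acceptors where the old group had 0, and the loss is smaller than a 40-fold lower number from compound 1 to compound 2 (1.60 log units; beyond the scatter) seen on the sulfonyl sulfur. Nothing measured here explains why the number rises.

Because the chlorine and trifluoromethyl leave together as the methylsulfonyl enters, these compounds cannot show which of the three changes accounts for the step. A phenyl ring carrying only chlorine, or a carboxylic acid in place of the methylsulfonyl, would help to separate them.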